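The compounds below may be only part of what the source reports. "The series", "measured", "known", "first", "only" and "open" are said of these compounds alone.

The account begins with compound 1, `Cc1ccc2nc(N3CCCc4ccc(F)cc4C3)cc(NCC3(N)COC3)c2c1`, whose cytotoxicity toward human cells was examined in an ADME assay on HEp-2 cells (Homo sapiens) for cytotoxicity, read by CCK-8 assay, with a stated time of 5 days; a lower number here means that less compound is tolerated, a higher number that more compound is tolerated. In this assay compound 1 gives > 100000 nM, which is a limit of the assay rather than a number. Two related compounds carry a plain ethylenediamine chain on the same core: compound 2, `NCCNc1cc(N2CCCc3ccccc3C2)nc2ccccc12`, gives 23000 nM, and compound 3, `NCCNc1cc(N2CCCc3ccccc3C2)nc2cc(Cl)ccc12`, gives 7500 nM. Between them lies a 3.1-fold lower number from compound 2 to compound 3 (0.49 log units; beyond the scatter), the only measured step, and it concerns an aromatic substituent rather than the side chain. The compound awaiting measurement is compound 4, `CC(=O)NCCNc1cc(N2CCCc3ccc(F)cc3C2)nc2ccc(C)cc12`. It differs from compound 1 by acetamidomethyl in place of 3-aminooxetan-3-yl on a saturated chain carbon bound to a nitrogen on an aromatic ring. Going by the values given here, no measured step touches this change, so the expected step of a number no higher from compound 1 to compound 4 (the limit leaves the size open) rests on compound 1 alone, with the limit of > 100000 nM in this assay, at which 1 of the 3 values shown sits, as the only guide. Compound 4 is therefore estimated at 100000 nM, within 30000 nM to 300000 nM.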

Compound 4, half-maximal cytotoxic concentration: 66000 nM
The estimate for compound 4 lay 1.5-fold (0.18 log units) above the measured number; low and high end bracket the measured number.
By their numbers in this assay, from the lowest: compound 3; then compound 2; then compound 4. At a limit, above all of these: compound 1.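

Going by these compounds alone, the result is the first look at a change in the side chain, as the only earlier step concerned an aromatic substituent. In this assay, acetamidomethyl in place of 3-aminooxetan-3-yl gives an at least 1.5-fold lower number from compound 1 to compound 4 (0.18 log units; that floor lies within the scatter). The value of compound 1 is a limit and not a number, so the true size of this step cannot be read and no real change is shown: the limit of > 100000 nM in this assay, at which 1 of the 4 values shown sits.

On these data alone, whether a carboxylic acid or a longer chain at this place would give a step beyond the scatter stays open. So does whether the chloro step would carry over to the core of compound 1.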